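Swapping the Aryl Group on a Triazole Amide

This account rests on a few compounds, and the source may have more. Where it says the series, first, only, none or still open, it means among the compounds named here.

Measured so far:
compound 1, `COc1cc2c(Oc3ccc(NC(=O)c4nnn(-c5ccccc5C)c4C)cc3F)ccnc2cc1OCCCN1CCCC1`, 380 nM
compound 2, `COc1cc2c(Oc3ccc(NC(=O)c4nnn(-c5ccc(F)cc5)c4C(F)(F)F)cc3F)ccnc2cc1OCCCN1CCCC1`, 80 nM

Both compounds share one core and were tested in a functional assay on A549 cells (Homo sapiens) for cytotoxicity, read by MTT assay, with a stated time of 72 h; a higher number here means a weaker inhibitor, a lower number a stronger inhibitor. Compound 2 gives 80 nM, the lowest of the two numbers, and compound 1 gives 380 nM, a gap that lies beyond the usual scatter. The two differ in more than one place, so the numbers alone do not say which part of the change matters.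

Compound 3, `COc1cc2c(Oc3ccc(NC(=O)c4nnn(-c5ccccc5C(F)(F)F)c4C(F)(F)F)cc3F)ccnc2cc1OCCCN1CCCC1`, has not been measured. It differs from compound 2 in one place: 2-(trifluoromethyl)phenyl in place of 4-fluorophenyl on an aromatic nitrogen.

For the measured compounds named here, no single-change step between measured compounds is available to guide this. Going by the values given here, compound 1, the only other compound, carries a group at the same position of its phenyl ring and gives 380 nM, but it also differs on the triazole. The expected step from compound 2 to compound 3 is therefore a 1.9-fold higher number from compound 2 to compound 3 (0.27 log units; within the scatter), a modest weakening that may not exceed the scatter. Compound 3 is estimated at 150 nM, within 40 nM to 550 nM.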

Compound 3, half-maximal inhibitory concentration: 200 nM
Compound 3: the middle estimate sits 1.3-fold (0.12 log units) below what was measured, and the stated range covers the measured number.
By their numbers in this assay, from the lowest: compound 2; then compounds 3 and 1 (each within the scatter of the next).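

In this assay, for the compounds shown here, this pair gives the first single-place change in the set: a 2.5-fold higher number from compound 2 to compound 3 (0.40 log units; beyond the scatter), so the aryl group on this aromatic nitrogen affects the number even with the rest of the molecule held fixed. The step is modest, so this position accepts 2-(trifluoromethyl)phenyl in place of 4-fluorophenyl with a limited loss rather than a collapse in activity. No measurement here explains the step.

The swap changes both the group on the phenyl ring and its place on that ring, and the compounds shown cannot separate those two changes. A 4-(trifluoromethyl)phenyl or a 2-fluorophenyl group on the same nitrogen would show how much each change contributes.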